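Swapping a substituted phenyl for a phenoxy group

This account rests on a few compounds, and the source may have more. Where it says the series, first, only, none or still open, it means among the compounds named here.

Three compounds share a core built around a sulfonamide linked to a dimethylpiperazine-bearing aniline, and all were tested in a functional assay for agonist activity at growth hormone secretagogue receptor type 1 (Homo sapiens), read by FLIPR; a lower number here means that less compound is needed, a higher number that more compound is needed for the effect. Compound 1 `C[C@@H]1CN(c2cccc(NS(=O)(=O)c3ccc(-c4ccccn4)s3)c2)C[C@H](C)N1` gives 39.8 nM. Compound 3 `COc1ccc(N2C[C@@H](C)N[C@@H](C)C2)cc1NS(=O)(=O)c1ccc(-c2cnco2)s1` gives 2.51 nM. Compound 2 `COc1ccc(F)c(-c2ccc(S(=O)(=O)Nc3cc(N4C[C@@H](C)N[C@@H](C)C4)ccc3OC)cc2)c1` gives 0.398 nM, the lowest number of the three and therefore the most potent of the set, standing clearly apart from both others.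

Compound 4 `COc1ccc(N2C[C@@H](C)N[C@@H](C)C2)cc1NS(=O)(=O)c1ccc(Oc2ccccc2)cc1` is the next compound to consider; it has not yet been measured. It differs from compound 2 in one place: phenoxy in place of 2-fluoro-5-methoxyphenyl on an aromatic carbon. The group that leaves is the larger one, carrying a fluorine and a methoxy on its ring; the group that enters is a plain phenoxy.

Within the data shown here, no pair of measured compounds isolates exactly this change, so the expectation rests on the gap between compound 2 and the rest. A move away from the best value is expected, with a step of an 8.0-fold higher number from compound 2 to compound 4 (0.91 log units; beyond the scatter) in this assay. Compound 4 is expected to give about 3.2 nM in this assay, within a range from 0.6 nM to 16 nM.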

Compound 4, half-maximal effective concentration: 63.1 nM
Compound 4: middle estimate off by 20-fold (1.29 log units), on the low side; the whole stated range lies below it.
By their numbers in this assay, from the lowest: compound 2; then compound 3; then compounds 1 and 4 (each within the scatter of the next).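

Phenoxy in place of 2-fluoro-5-methoxyphenyl gives a 160-fold higher number from compound 2 to compound 4 (2.20 log units; beyond the scatter) in this assay, the first single-place comparison in this set. This shows that the group on this aromatic carbon, para to a large group, has a strong bearing on how much compound is needed for the effect, even though both groups carry one six-membered aromatic ring and one hydrogen-bond acceptor and have no net charge. No measurement shown here explains the size of this step.

The swap alters the fluorine, the methoxy and the oxygen in phenoxy together, so the compounds shown leave open which of these differences matters. A plain phenyl group at this place, or a phenyl carrying only the fluorine or only the methoxy, would help to separate them.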